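The source may report more compounds than this note shows. Statements on the series, on what has been measured and on what is new or still open speak of the compounds shown alone.

Compound 1, `Cc1ccccc1COc1ccc(-c2cc(CN3CCN(Cc4ccc(C(F)(F)F)cc4)CC3)no2)cc1`, in a functional assay on MCF7 cells (Homo sapiens) for antiproliferative activity, read by sulforhodamine B assay, with a stated time of 72 h (a higher number here means a weaker inhibitor, a lower number a stronger inhibitor), gives 3700 nM.
Compound 2, `Cc1cccc(COc2ccc(-c3cc(CN4CCN(Cc5ccc(C(F)(F)F)cc5)CC4)no3)cc2)c1`, in this assay gives 4000 nM.

Compound 2 and compound 1 lie within the scatter of each other, separated only by a 1.1-fold higher number from compound 1 to compound 2 (0.03 log units; within the scatter), so neither can be ranked against the other. Compound 3, `Fc1cccc(COc2ccc(-c3cc(CN4CCN(Cc5ccc(C(F)(F)F)cc5)CC4)no3)cc2)c1`, differs from compound 2 by fluoro in place of methyl on an aromatic carbon. Within the data shown here, the single measured step, 3-methylphenyl in place of 2-methylphenyl, concerns the placement of methyl rather than its replacement by fluoro, and so bears only loosely on this change; no step in the set tests fluoro at all. On this thin basis no movement beyond the scatter is expected. Compound 3 is estimated at 4000 nM, with a range of 2000 nM to 8000 nM. The expected step is no change at the digits printed from compound 2 to compound 3 (within the scatter).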

Compound 3, half-maximal inhibitory concentration: 2500 nM
The estimate for compound 3 lay 1.6-fold (0.20 log units) above the measured number, within the range that was stated.
By their numbers in this assay, from the lowest: compounds 3, 1 and 2 (each within the scatter of the next).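

Fluoro in place of methyl on this aromatic carbon gives a 1.6-fold lower number from compound 2 to compound 3 (0.20 log units; within the scatter) in this assay, so at this position fluoro cannot be told apart from methyl. Against the 2-methylphenyl compound, the 3-fluorophenyl group gives a 1.5-fold lower number from compound 1 to compound 3 (0.17 log units; within the scatter), so the three compounds so far form one group within the scatter. Nothing available here bears on the reason for these small steps.

Open, going by these compounds, is whether a methoxy group, a nitrile or an amine on this aromatic carbon would move the number beyond the scatter. Also open, on these data alone, is whether any group at this position separates from methyl and fluoro.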